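From Ethyl to Fluoro: Expecting Only a Small Step

The source may hold more compounds than are shown below. What is called first, only, known or untested is meant among the compounds shown, and "the series" means these compounds.

For the measured compounds named here, in a functional assay on SMMC-7721 cells (Homo sapiens) for antiproliferative activity, read by CCK-8 assay, with a stated time of 72 h (a higher number here means a weaker inhibitor, a lower number a stronger inhibitor), compound 1 (`CCc1ccc(SCc2ccc(C(=O)Nc3ccccc3N)cc2)cc1`) gives 1750 nM as the only number so far, which leaves nothing to rank it against. Compound 2 (`Nc1ccccc1NC(=O)/C=C/c1ccc(CSc2ccc(F)cc2)cc1`) stands at "not determined" (no result reported) and so offers no comparison. Compound 3 (`Nc1ccccc1NC(=O)c1ccc(CSc2ccc(F)cc2)cc1`) keeps the core of compound 1 and differs in one place (fluoro in place of ethyl on an aromatic carbon), para to a large group. A 4-ethylphenyl thus becomes a 4-fluorophenyl. Going by the values given here, no measured pair shows what this swap does here, so the expectation starts from compound 1 at 1750 nM and has little else to lean on. The expected change (a 1.1-fold higher number from compound 1 to compound 3 (0.04 log units; within the scatter)) stays within the usual scatter of repeated measurements, with no direction favoured. For compound 3 the estimated value is 1900 nM with an expected range from 650 nM to 5500 nM in this test.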

Compound 3, half-maximal inhibitory concentration: 5770 nM
Estimate against measurement, compound 3: 3.0-fold (0.48 log units) below; measured number above the stated range.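

In this assay, putting fluoro in place of ethyl on the aromatic carbon para to a large group is not a silent swap: it brings a 3.3-fold higher number from compound 1 to compound 3 (0.52 log units; beyond the scatter) and so takes the series to a weaker inhibitor. This position therefore responds to what sits on it, and of the two groups seen so far, ethyl goes with the stronger result, although this rests on a single pair of compounds. Nothing available explains the shift, so its cause remains unknown.

As far as these compounds go, it remains open whether a propyl chain, a methoxy group or an amine on this same carbon would give a number nearer to that of compound 1 or that of compound 3. Compound 2 has no reported result, so it cannot show whether the same swap behaves alike in a compound with a different link to the amide.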